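Methoxy for Methyl on a Weakly Active Benzyl Amide

The source may hold more compounds than are shown below. What is called first, only, known or untested is meant among the compounds shown, and "the series" means these compounds.

Compound 1 `COc1ccc(CN(C(=O)CSc2nc3cc(Br)ccc3s2)c2cc(OC)c(OC)c(OC)c2)cc1O` is the only one of the two measured compounds that gives a number: in a functional assay on HCT-116 cells (Homo sapiens) for antiproliferative activity, read by MTT assay, with a stated time of 48 h (a lower number here means a stronger inhibitor, a higher number a weaker inhibitor), compound 1 gives 3380 nM. Compound 2 `COc1cc(N(Cc2ccc(C)cc2)C(=O)CSc2nc3ccccc3s2)cc(OC)c1OC` stands apart. In this assay compound 2 reaches only a limit of the assay, > 80000 nM, not a measured number. Its place is given by the limit of > 80000 nM in this assay, at which 1 of the 2 values shown sits.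

Compound 3 `COc1ccc(CN(C(=O)CSc2nc3ccccc3s2)c2cc(OC)c(OC)c(OC)c2)cc1` differs from compound 2 in a single spot: methoxy in place of methyl on an aromatic carbon. Among the measured compounds shown here, no measured pair of compounds that differ in one place is available, so the size of this change has to be judged from the two values alone. Compound 1 also carries a methoxy on its benzyl ring and gives a number, though it differs from compound 3 in more than one place. The step from compound 2 to compound 3 is expected to be an at least 2.6-fold lower number from compound 2 to compound 3 (0.42 log units; beyond the scatter), toward stronger inhibition. Compound 3 is therefore estimated at 30000 nM, with a range from 5000 nM to 80000 nM, and it may again land at a limit.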

Compound 3, half-maximal inhibitory concentration: 426 nM
Estimate against measurement, compound 3: 70-fold (1.85 log units) above; the whole stated range lies above it.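

In this assay, replacing the 4-methylbenzyl group with a 4-methoxybenzyl group gives an at least 180-fold lower number from compound 2 to compound 3 (2.27 log units; beyond the scatter). This shows that the position para to a large group is far from indifferent to what sits there: a change of a single methyl to a methoxy is enough to turn a compound without a measured number into one with a clear value. The step is a lower bound, and its real size cannot be read, since the value of compound 2 is a limit and not a number: the limit of > 80000 nM in this assay, at which 1 of the 3 values shown sits.

Still open, going by these compounds, is how a hydroxy, an ethoxy or an amine at this same position would compare with the methoxy of compound 3. Also open, on these data alone, is whether moving the methoxy elsewhere on the ring would keep the gain.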